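The source may hold more compounds than are shown below. What is called first, only, known or untested is meant among the compounds shown, and "the series" means these compounds.

Three compounds that share one fused two-ring core were tested in a functional assay on CHO cells for antagonist activity at metabotropic glutamate receptor 5 (Rattus norvegicus), read by FLIPR and calcium flux; on this read-out lower numbers stand for stronger inhibition and higher numbers for weaker inhibition. Compound 1 `Cc1ccc2cnc(-c3ccccc3)nc2n1` carries a plain phenyl ring and gives 2700 nM. Compound 2 `Cc1ccc2cnc(-c3cccc(C#N)c3)nc2n1` bears a cyano group on that phenyl ring, and in this assay compound 2 gives 240 nM. Compound 3 `Cc1cccc(-c2ncc3ccc(C)nc3n2)c1` bears a methyl group at the same spot and in this assay gives 53 nM. The substituent on the phenyl ring matters a great deal: hydrogen in place of methyl on an aromatic carbon gives a 51-fold higher number from compound 3 to compound 1 (1.71 log units; beyond the scatter), while an 11-fold lower number from compound 1 to compound 2 (1.05 log units; beyond the scatter) and a 4.5-fold lower number from compound 2 to compound 3 (0.66 log units; beyond the scatter).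

Compound 4 `N#Cc1cccc(-c2ncc3cccnc3n2)c1` has not yet been measured. It differs from compound 2 by hydrogen in place of methyl on an aromatic carbon. The same kind of change is seen between compound 3 and compound 1, with hydrogen in place of methyl on an aromatic carbon, where it made a 51-fold higher number from compound 3 to compound 1 (1.71 log units; beyond the scatter). The two cores differ by cyano in place of methyl on an aromatic carbon. The place, however, is not the same: in compound 3 the methyl sits on a six-membered aromatic ring of carbon only, meta to a large group, whereas in compound 2 it sits on a six-membered aromatic ring with 1 nitrogen, part of a fused or bridged system of two rings, next to the ring nitrogen, meta to a fused ring and para to a fused ring. So this is the same kind of change, not the same change.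

A smaller loss is expected for compound 4, about a 3.8-fold higher number from compound 2 to compound 4 (0.57 log units; beyond the scatter), because a 51-fold higher number from compound 3 to compound 1 (1.71 log units; beyond the scatter) shows that removing a methyl can cost much, yet here it is removed from a different ring. Compound 4 is therefore estimated to give about 900 nM, expected to lie between 250 nM and 4000 nM.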

Compound 4, half-maximal inhibitory concentration: > 26100 nM
Compound 4 was reported as a limit; the forecaster's own chance of this, stated with the estimate: 5%; middle value at least 29-fold (1.46 log units) from the limit.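

In this assay compound 4 gives > 26100 nM, which is a limit of the assay and not a number. Putting hydrogen in place of the methyl on the ring with 1 nitrogen gives an at least 100-fold higher number from compound 2 to compound 4 (2.03 log units; beyond the scatter), so in this pair too the change is large and goes in the same direction as the earlier step, even though the methyl leaves a different ring: the same change on two cores in this assay, a 51-fold higher number (1.71 log units; beyond the scatter) from compound 3 to compound 1 and an at least 100-fold higher number (2.03 log units; beyond the scatter) from compound 2 to compound 4; the limit leaves it open whether they differ. This does not show how large the loss from compound 2 to compound 4 really is, and two pairs with the methyl in different places make no rule for other cores, so all that carries over is that losing either methyl weakened inhibition in these pairs; the size of the new step rests on a limit: the limit of > 26100 nM in this assay, at which 1 of the 4 values shown sits.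

The compounds shown leave open whether an ethyl group, a longer chain or an amine on that aromatic carbon, next to the ring nitrogen, would keep the inhibition that the methyl gives. They also leave open how a core without this methyl behaves when the phenyl ring carries the methyl group of compound 3 rather than the cyano group of compound 4.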